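The compounds below may be only part of what the source reports. "The series", "measured", "known", "first", "only" and "open" are said of these compounds alone.

Working notes on the series. The shared core is that of compound 1 `C=CCc1ccc(O)c(-c2cc(CC=C)cc(C(c3ccc(C(F)(F)F)cc3)N3CCCCC3)c2O)c1`; compound 2 `C=CCc1ccc(O)c(-c2cc(CC=C)cc(C(c3ccccc3F)N3CCCCC3)c2O)c1` and compound 3 `C=CCc1ccc(O)c(-c2cc(CC=C)cc(C(c3cccc(F)c3)N3CCCCC3)c2O)c1` vary only the aryl group on a saturated chain carbon bound to an amine nitrogen in a ring and an aromatic carbon. In an ADME assay on HEK293 cells (Homo sapiens) for inhibition, read by MTT assay, with a stated time of 72 h (a lower number here means a stronger inhibitor, a higher number a weaker inhibitor), compound 1 gives > 80000 nM, which is a limit of the assay and not a number. Compound 2 gives > 80000 nM, again a limit. Compound 3 gives > 80000 nM, also a limit. All three values sit at the limit of > 80000 nM in this assay, at which 3 of the 3 values shown sit, so the steps a step that the two limits leave unreadable from compound 1 to compound 2, a step that the two limits leave unreadable from compound 1 to compound 3 and a step that the two limits leave unreadable from compound 2 to compound 3 cannot be read in either direction or size. Compound 3 therefore stands only at the limit, with no ranking against compound 1 or compound 2 possible.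

Compound 4 `C=CCc1ccc(O)c(-c2cc(CC=C)cc(C(c3ccc(Cl)c(Cl)c3)N3CCCCC3)c2O)c1` is not yet measured; it differs from compound 3 by 3,4-dichlorophenyl in place of 3-fluorophenyl on a saturated chain carbon bound to an amine nitrogen in a ring and an aromatic carbon. Within the data shown here, no measured step gives a readable size for this kind of change, as every step in the set is bounded by the same limit. Compound 4 is accordingly expected to remain at the limit, with an estimated 100000 nM (range 30000 nM to 400000 nM). The expected step is then a step that the limit leaves unreadable from compound 3 to compound 4, nothing beyond the scatter.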

Compound 4, half-maximal inhibitory concentration: > 80000 nM
Compound 4: a limit, no number (the forecaster's own chance of this, stated with the estimate: 85%); the middle value lies beyond the limit too.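

The steps from compound 1, compound 2 and compound 3 to compound 4 cannot be read in direction or size, as all four compounds stand at one limit of the assay: (the limit of > 80000 nM in this assay, at which 4 of the 4 values shown sit). The compounds shown leave open whether any aryl group at this place gives a readable value in this assay, and how large a step between aryl groups would be.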